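A shorter chain end on compound 1

The compounds below may be only part of what the source reports. "The series", "measured", "known", "first", "only" and "open" are said of these compounds alone.

Compound 1 `C#C/C=C\CCCCCCCCCCCCCCC/C=C\CCCC/C=C\CCCCC#C[C@@H](O)C#CCCCCCC/C=C/[C@H](O)C#C` gives 2.5 ug/mL
Compound 2 `C#CCCCCCCCCCCCCCCCC/C=C\CCCC/C=C\CC/C=C/C#C[C@@H](O)C#CCCCCCC/C=C/[C@H](O)C#C` gives 3.4 ug/mL
Compound 3 `C#C/C=C\CCCCCCCCCCCCCC/C=C\CCCC/C=C\CCCCc1cc(=O)cc(CCCCCC/C=C/C(O)C#C)o1` gives > 10 ug/mL as a limit, not a number

In a functional assay on XF498 cells (Homo sapiens) for cytotoxicity (on this read-out lower numbers stand for an effect already at smaller amounts and higher numbers for an effect only at larger amounts of compound), compound 1 stands at 2.5 ug/mL and compound 2 at 3.4 ug/mL as values that lie within the usual scatter of each other. Compound 3 shows only the limit > 10 ug/mL and no exact number.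

The not yet measured compound 4 `C#C/C=C\CCCCCCCCCCCCC/C=C\CCCC/C=C\CCCCC#C[C@@H](O)C#CCCCCCC/C=C/[C@H](O)C#C` differs from compound 1 in one place (a group of 4 heavy atoms (4 carbon; no ring) in place of a group of 6 heavy atoms (6 carbon; no ring), on a saturated chain carbon, ten or more bonds along the chain from a double-bonded chain carbon). For the measured compounds named here, no measured pair differs in just one place, so the data give no direct guide to the size of such a step. The expectation therefore starts from compound 1 at 2.5 ug/mL and foresees no change beyond the scatter in this assay in either direction. The expected step is a 1.1-fold higher number from compound 1 to compound 4 (0.05 log units; within the scatter) and so stays within the scatter. Compound 4 is estimated at 2.8 ug/mL with an expected range from 1.3 ug/mL to 6 ug/mL for repeated measurements.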

Compound 4, concentration for half-maximal effect: 6.1 ug/mL
Estimate against measurement, compound 4: 2.2-fold (0.34 log units) below; the whole stated range lies below it.
By their numbers in this assay, from the lowest: compounds 1, 2 and 4 (each within the scatter of the next, the first and the last beyond it). At a limit, above all of these: compound 3.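

For the compounds shown here, this is the first step in this assay that changes only one place, and it shows that this place is sensitive to the size of the group: the step is a 2.4-fold higher number from compound 1 to compound 4 (0.39 log units; beyond the scatter), which is modest but beyond the usual scatter. The group of 4 heavy atoms keeps the double bond and the triple bond of the group of 6 heavy atoms, so the count of heavy atoms is what differs here, and the smaller group needs more compound for the same effect. Compound 4 still gives an exact number, so the full size of the step can be read, and the limit of the read-out is not reached here: the limit of > 10 ug/mL in this assay, at which 1 of the 4 values shown sits.

A single step cannot show whether a longer chain in this place would bring the number down further or whether the effect already peaks with the group of 6 heavy atoms. Going by these compounds, how an amine or a carboxylic acid would behave on this saturated chain carbon also remains open.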